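A few compounds are considered here, and "the series" means these few. Any claim that something is new, unique, unknown or untested is made for them only; others in the source may bear on it.

Measured compounds:
compound 1 `COc1ccc(Nc2cncc(N3CC4CC(C3)N4)c2)cc1`: 0.0598 nM
compound 2 `Clc1ccc(Nc2ccc(N3CC4CC(C3)N4)cn2)cc1`: 2.49 nM
compound 3 `Oc1ccc(Nc2ccc(N3CC4CC(C3)N4)cn2)cc1`: 7.1 nM

In an assay on cell membranes for displacement of a labelled ligand from Neuronal acetylcholine receptor; alpha4/beta2 (Rattus norvegicus) (a lower number here means a stronger inhibitor, a higher number a weaker inhibitor), compound 1 gives the lowest number of the three, compound 2 a clearly higher one and compound 3 the highest. Compound 4 `FC(F)(F)c1ccc(Nc2cncc(N3CC4CC(C3)N4)c2)cc1` is a close variant of compound 1: trifluoromethyl in place of methoxy on an aromatic carbon. Within the data shown here, the only measured single-change step is a 2.9-fold higher number from compound 2 to compound 3 (0.46 log units; beyond the scatter), which exchanges a different pair of groups on a differently arranged version of the shared core, so it does not bear directly on the methoxy-to-trifluoromethyl exchange. Without a direct precedent, a modest weakening is expected from compound 1 to compound 4, namely a 4.2-fold higher number from compound 1 to compound 4 (0.62 log units; beyond the scatter). Compound 4 is therefore estimated at 0.25 nM, with a range from 0.04 nM to 1.5 nM.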

Compound 4, inhibition constant: 0.373 nM
Estimate against measurement, compound 4: 1.5-fold (0.17 log units) below; measured number inside the range.
By their numbers in this assay, from the lowest: compound 1; then compound 4; then compound 2; then compound 3.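

In this assay, trifluoromethyl in place of methoxy, para to a large group, gives a 6.2-fold higher number from compound 1 to compound 4 (0.80 log units; beyond the scatter), a modest loss. This position therefore accepts a group with more heavy atoms and no hydrogen-bond acceptor, and compound 4 still reaches 0.373 nM. No measurement here explains why the number rises.

Still open, going by these compounds, is how an amine or a carboxylic acid at this position would compare with methoxy and trifluoromethyl. On these data alone, it is also open whether the same exchange would have a similar effect on the differently arranged core of compound 2.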